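This account rests on a few compounds, and the source may have more. Where it says the series, first, only, none or still open, it means among the compounds named here.

Within the data shown here, in a physicochemical assay for lipophilicity, at pH 7.4 (a higher number here means a more lipophilic compound, a lower number a more polar compound), compound 1 (`CCOc1ccc2c(c1)C=CN(C)C(=O)C2C`) gives 5, the highest of the three numbers measured so far. Compound 2 (`CC1C(=O)N(C)C=Cc2cc(OCC(C)(C)O)ccc21`) gives 3.6 and compound 3 (`CCOc1ccc2c(c1)C(c1cn[nH]c1)=CN(C)C(=O)[C@@H]2C`) gives 3.4. Compound 4 (`CCOc1ccc2c(c1)C(n1ccnc1)=CN(C)C(=O)C2C`) has 1H-imidazol-1-yl in place of hydrogen on a double-bonded ring carbon of compound 1: 1H-imidazol-1-yl in place of hydrogen on a double-bonded ring carbon. Among the measured compounds shown here, the only measured step, a number 1.40 log units lower from compound 1 to compound 2 (beyond the scatter), is large but concerns a different place, so it bears on this change only loosely. The value of compound 3, 3.4, is a further guide and also lies well under that of compound 1. A large fall in this assay is therefore expected, namely a number 1.30 log units lower from compound 1 to compound 4 (beyond the scatter). For compound 4 the estimated value is 3.7, with an expected range from 3.1 to 4.3.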

Compound 4, distribution coefficient: 4.3
Estimate against measurement, compound 4: 0.60 log units below, and the stated range covers the measured number.
By their numbers in this assay, from the lowest: compounds 3 and 2 (each within the scatter of the next); then compound 4; then compound 1.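

In this assay, 1H-imidazol-1-yl in place of hydrogen on the double-bonded ring carbon gives a single-place step at this position, a number 0.70 log units lower from compound 1 to compound 4 (beyond the scatter), modest but beyond the scatter. This step is smaller than the large one on the chain, a number 1.40 log units lower from compound 1 to compound 2 (beyond the scatter). No measurement given here explains the size of the step. From the compounds shown here alone, it remains open how an amine or a carboxylic acid on this carbon would compare, and whether the step would hold with 1-hydroxy-1-methylethyl on the chain.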